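The source may report more compounds than this note shows. Statements on the series, on what has been measured and on what is new or still open speak of the compounds shown alone.

Working notes on the oxime-amidine series against an assay on isolated protein for inhibition of Indoleamine 2,3-dioxygenase 1 (Homo sapiens), read by spectrophotometry, with a stated time of 1 h; a lower number here means a stronger inhibitor, a higher number a weaker inhibitor. Of the compounds shown here, three have numbers so far. Compound 1 `O=[N+]([O-])c1ccc(N/C(=N\O)c2ccccc2F)c2nonc12` gives 63 nM in this assay. Compound 2 `Cc1cccc(/C(=N/O)Nc2ccc([N+](=O)[O-])c3nonc23)c1` gives 163 nM. Compound 3 `O=[N+]([O-])c1ccc(N/C(=N\O)c2cccc(Br)c2)c2nonc12` gives 105 nM. Among these three, compound 3 holds the second highest number; its nearest neighbour is compound 2, with a 1.6-fold lower number from compound 2 to compound 3 (0.19 log units; within the scatter), and its furthest is compound 1, with a 1.7-fold higher number from compound 1 to compound 3 (0.22 log units; within the scatter), so compound 3 sits within the scatter of both. Within the data shown here, only the step of a 2.6-fold higher number from compound 1 to compound 2 (0.41 log units; beyond the scatter) exceeds the scatter.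

Compound 4 `Cc1ccc(/C(=N/O)Nc2ccc([N+](=O)[O-])c3nonc23)cc1` is the next member: 4-methylphenyl in place of 3-bromophenyl on a carbon with a double bond to nitrogen. The step that bears most directly on it is the swap of bromo for methyl on an aromatic carbon, seen as a 1.6-fold lower number from compound 2 to compound 3 (0.19 log units; within the scatter), which stayed within the scatter. Among the measured compounds shown here, no measured pair shows the 4-methylphenyl group itself, so the shift of the methyl to a new position is untested. With the available evidence pointing to an indifferent exchange, the expectation for a 1.2-fold higher number from compound 3 to compound 4 (0.09 log units; within the scatter) is a step of no meaningful size. Compound 4 is estimated at 130 nM, with a range of 55 nM to 320 nM.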

Compound 4, half-maximal inhibitory concentration: 204 nM
Compound 4: the middle estimate sits 1.6-fold (0.20 log units) below what was measured; the measured number falls inside the stated range.
By their numbers in this assay, from the lowest: compounds 1, 3, 2 and 4 (each within the scatter of the next, the first and the last beyond it).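

The 4-methylphenyl group now has a reading on this carbon with a double bond to nitrogen in this assay: exchanging 3-methylphenyl for it gives a 1.3-fold higher number from compound 2 to compound 4 (0.10 log units; within the scatter) and exchanging 3-bromophenyl for it gives a 1.9-fold higher number from compound 3 to compound 4 (0.29 log units; within the scatter), so neither change separates from the scatter. Only the exchange of 2-fluorophenyl for 4-methylphenyl clears the scatter, with a 3.2-fold higher number from compound 1 to compound 4 (0.51 log units; beyond the scatter), and this adds a second methylphenyl step beyond the scatter to a 2.6-fold higher number from compound 1 to compound 2 (0.41 log units; beyond the scatter), while compound 3 remains within the scatter of compound 1. No measurement at hand offers an explanation for these differences.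

The compounds shown leave open how an amine, a carboxylic acid or a longer alkyl chain on the phenyl ring would read at this carbon. Among these compounds, they also leave open whether the gap to compound 1 follows the fluoro group itself or its place on the ring, as compound 1 is the only fluoro member.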